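Shorter Branched Ether Chain on a Second Core

This account rests on a few compounds, and the source may have more. Where it says the series, first, only, none or still open, it means among the compounds named here.

Measured compounds:
Compound 1, `CCCCCCOc1nc(C(C)(C)C)ccc1CNC(=O)C(C)c1ccc(NS(C)(=O)=O)c(F)c1`: 2.7 nM
Compound 2, `CC(C)COc1nc(C(C)(C)C)ccc1CNC(=O)C(C)c1ccc(NS(C)(=O)=O)c(F)c1`: 0.6 nM
Compound 3, `CCCCCCOc1cc(C(C)(C)C)ccc1CNC(=O)C(C)c1ccc(NS(C)(=O)=O)c(F)c1`: 0.5 nM

All three were tested in an assay on cells for antagonist activity at transient receptor potential cation channel subfamily V member 1 (Homo sapiens), read by FLIPR and calcium flux, with a stated time of 6 min; on this read-out lower numbers stand for stronger inhibition and higher numbers for weaker inhibition. Compound 1 and compound 2 share one core; compound 3 carries a different core, and the difference between the two cores is not broken down here. Compound 1 and compound 2 differ in one place: isopropyl in place of pentyl on a saturated chain carbon bound to an oxygen on an aromatic ring. That change gave a 4.5-fold lower number from compound 1 to compound 2 (0.65 log units; beyond the scatter), a clear gain in potency.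

Compound 4, `CC(C)COc1cc(C(C)(C)C)ccc1CNC(=O)C(C)c1ccc(NS(C)(=O)=O)c(F)c1`, has not yet been measured. It stands to compound 3 exactly as compound 2 stands to compound 1: isopropyl in place of pentyl on a saturated chain carbon bound to an oxygen on an aromatic ring. The change sits in the same place on both cores, so the same step is the natural starting point. Compound 3 already gives a low number in this assay, and the nearest measured neighbour, compound 2, sits within the scatter of it, so there is little room to judge how far a further gain could go. The expectation for compound 4 is therefore a step in the same direction as the earlier one, a 2.5-fold lower number from compound 3 to compound 4 (0.40 log units; beyond the scatter), but drawn somewhat closer to the value of compound 3 than a straight copy of the step from compound 1 to compound 2 would give. Compound 4 is estimated at 0.2 nM, with a likely range from 0.08 nM to 0.6 nM.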

Compound 4, inhibition constant: 2.1 nM
The estimate for compound 4 lay 11-fold (1.02 log units) below the measured number, outside the stated range (above it).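

In this assay, replacing the hexyloxy chain with the shorter, branched isobutoxy chain on the core of compound 3 gave a 4.2-fold higher number from compound 3 to compound 4 (0.62 log units; beyond the scatter), a loss of potency where the same change on the core of compound 1 had brought a gain. The two steps run in opposite directions, and the gap between them is too large to put down to ordinary variation between repeated measurements: the same change on two cores in this assay, a 4.5-fold lower number (0.65 log units; beyond the scatter) from compound 1 to compound 2 and a 4.2-fold higher number (0.62 log units; beyond the scatter) from compound 3 to compound 4, 19-fold (1.28 log units) apart, beyond the scatter of two such steps. Within the data shown here, this shows that, in this series, the effect of the change on one core cannot simply be copied to the other, but it does not show why, since the difference between the two cores is not broken down and each core supplies only one pair of compounds.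

On these data alone, it remains open whether the reversal belongs to these two chains alone or would also appear with other groups in the same place, such as a straight butyl chain, a cyclopropylmethyl group or a chain ending in an amine. Also unresolved is which feature of the two cores decides the direction of the step, a question that a single pair on each core cannot settle.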